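This account rests on a few compounds, and the source may have more. Where it says the series, first, only, none or still open, it means among the compounds named here.

Among the measured compounds shown here, compound 1 `CC(C)OC(=O)c1sc(Nc2ncccn2)nc1-c1cnccn1` is one of two compounds measured in a functional assay on Huh-7 cells (Homo sapiens) for cytotoxicity, read by MTT assay, with a stated time of 72 h (on this read-out higher numbers stand for lower toxicity in this test and lower numbers for higher toxicity in this test), where compound 1 gives 110 nM, the lowest of the two numbers. For the measured compounds named here, its only neighbour, compound 2 `CC(C)OC(=O)c1sc(Nc2ncccn2)nc1-c1ncccn1`, gives 1620 nM in this assay, and the step of a 15-fold higher number from compound 1 to compound 2 (1.17 log units; beyond the scatter) comes from pyrimidin-2-yl in place of pyrazin-2-yl on an aromatic carbon. Compound 3 `CC(C)OC(=O)OCN(c1ncccn1)c1nc(-c2cnccn2)c(C(=O)OC(C)C)s1` has not yet been measured. It differs from compound 1 by ((isopropoxycarbonyl)oxy)methyl in place of hydrogen on a nitrogen on an aromatic ring; the new group has no ring and carries three hydrogen-bond acceptors and no donor. Going by the values given here, no measured step bears on this place: the one step available concerns an exchange of rings on an aromatic carbon, not a substituent on a nitrogen on an aromatic ring. The step from compound 1 is therefore expected to be a 1.8-fold higher number from compound 1 to compound 3 (0.26 log units; within the scatter), with no clear direction and wide uncertainty. Compound 3 is estimated at 200 nM, within 50 nM to 1000 nM.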

Compound 3, half-maximal cytotoxic concentration: 95 nM
Estimate against measurement, compound 3: 2.1-fold (0.32 log units) above; the measured number falls inside the stated range.
By their numbers in this assay, from the lowest: compounds 3 and 1 (each within the scatter of the next); then compound 2.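

In this assay, ((isopropoxycarbonyl)oxy)methyl in place of hydrogen on a nitrogen on an aromatic ring gives a 1.2-fold lower number from compound 1 to compound 3 (0.06 log units; within the scatter) and so stays within the scatter. Among the compounds shown here, this is the first reading at this position, and it shows that the hydrogen there can give way to this much larger group, which adds 8 heavy atoms, without a step beyond the scatter. The only such step among these compounds remains the ring exchange on an aromatic carbon, a 15-fold higher number from compound 1 to compound 2 (1.17 log units; beyond the scatter), and no measurement in hand accounts for either result.

From the compounds shown here alone, it remains open whether a plain methyl, an acetyl or a chain ending in an amine on this nitrogen would behave the same way. Also open, going by these compounds, is whether ((isopropoxycarbonyl)oxy)methyl would give a similar step on compound 2, which carries pyrimidin-2-yl in place of pyrazin-2-yl.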